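Swapping the Indolyl Group of Compound 3 for Methylphenyl

The source may report more compounds than this note shows. Statements on the series, on what has been measured and on what is new or still open speak of the compounds shown alone.

Compounds measured so far in a functional assay on B16-F0 cells (Mus musculus) for inhibition, read by CCK-8 assay, with a stated time of 48 h; a higher number here means a weaker inhibitor, a lower number a stronger inhibitor:
compound 1 `COc1cc(-c2ccnc3c(-c4ccc(C)cc4)cnn23)cc(OC)c1OC` gives > 10000 nM, a limit of the assay.
compound 2 `COc1cc(-c2ccnc3cc(-c4ccc(C(C)(C)C)cc4)nn23)cc(OC)c1OC` gives > 10000 nM, a limit of the assay.
compound 3 `COc1cc(-c2ccnc3cc(-c4ccc5ccn(C)c5c4)nn23)cc(OC)c1OC` gives 657 nM.

Going by the values given here, compound 3 stands alone in this set as the only compound with a measured number; the other two values sit at the limit of > 10000 nM in this assay, at which 2 of the 3 values shown sit. Among the compounds with values here, only one step is measured between compounds differing in one place: an at least 15-fold lower number from compound 2 to compound 3 (1.18 log units; beyond the scatter). That step shows the fused 1-methyl-1H-indol-6-yl group being the feature that brought the number down from the limit.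

Compound 4 `COc1cc(-c2ccnc3cc(-c4cccc(C)c4)nn23)cc(OC)c1OC` reverses the spirit of that step. The change is 3-methylphenyl in place of 1-methyl-1H-indol-6-yl on an aromatic carbon. The 3-methylphenyl group that enters is a single six-membered ring of carbon only, as are the 4-methylphenyl of compound 1 and the 4-(tert-butyl)phenyl of compound 2, both of which sit at the limit. Within the data shown here, the one measured step therefore points toward a rise in this assay for compound 4, with a fair chance that only a limit is reported again.

Compound 4 is expected to give about 6000 nM in this assay, within a range of 1500 nM to 25000 nM. This estimate corresponds to a 9.1-fold higher number from compound 3 to compound 4 (0.96 log units; beyond the scatter).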

Compound 4, half-maximal inhibitory concentration: 2220 nM
Compound 4: middle estimate off by 2.7-fold (0.43 log units), on the high side, within the range that was stated.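

In this assay, going by these compounds alone, the fused 1-methyl-1H-indol-6-yl group proves not to be the only group at this position that gives a measured number: a single six-membered ring of carbon only also does so, with 3-methylphenyl in place of 4-(tert-butyl)phenyl giving an at least 4.5-fold lower number from compound 2 to compound 4 (0.65 log units; beyond the scatter). The fused ring system still has the advantage, although a modest one, as replacing it with 3-methylphenyl gives a 3.4-fold higher number from compound 3 to compound 4 (0.53 log units; beyond the scatter). The step from compound 2 is a bound and not a size, as its starting value is a limit: the limit of > 10000 nM in this assay, at which 2 of the 4 values shown sit.

Going by these compounds, with only these groups at this position, it remains open whether the gain of compound 4 over compound 2 comes from the smaller methyl group or from where that group sits on the ring, a question that a plain phenyl or a 4-methylphenyl on the same core would address. Also open, on these data alone, is how a methoxy group or an amine in place of the methyl group of 3-methylphenyl would read, and whether an indol-6-yl without the methyl group on its ring nitrogen would keep the standing of compound 3.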